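Aryl variation on the saturated ring carbon: maximal response

The source may hold more compounds than are shown below. What is called first, only, known or untested is meant among the compounds shown, and "the series" means these compounds.

Measured so far:
compound 1 `FC(F)(F)c1c(CN2CCC(c3ccccc3)CC2)ccn2c(CC3CC3)nnc12` — 261%
compound 2 `FC(F)(F)c1c(CN2CCC(c3ccccc3Cl)CC2)ccn2c(CC3CC3)nnc12` — 328%

Both compounds share one core and differ only in the aromatic group on the saturated ring carbon. In an assay on CHO cells for positive allosteric modulation of metabotropic glutamate receptor 2 (Homo sapiens), read by scintillation counting, with a stated time of 30 min (on this read-out higher numbers stand for larger maximal responses and lower numbers for smaller maximal responses), compound 1 gives 261%, and compound 2 gives 328%. Among the measured compounds shown here, the single step, chloro in place of hydrogen on an aromatic carbon, moves the read-out by a number 67 percentage points higher from compound 1 to compound 2 (beyond the scatter). For the measured compounds named here, on the two numbers available compound 2 stands highest, with compound 1 the only neighbour, lower by a margin beyond the scatter.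

Compound 3 `Fc1cccc(F)c1C1CCN(Cc2ccn3c(CC4CC4)nnc3c2C(F)(F)F)CC1` is not yet measured. Its change from compound 2 is 2,6-difluorophenyl in place of 2-chlorophenyl on a saturated ring carbon, a 2,6-difluorophenyl in place of a 2-chlorophenyl on a saturated ring carbon. Going by the values given here, only the step of a number 67 percentage points higher from compound 1 to compound 2 (beyond the scatter) bears on this change, and only loosely: it shows that a substituted phenyl on that carbon gave a larger maximal response than the bare phenyl, but no step compares two different substituted phenyls. A step near zero or modestly downward is therefore expected, a number 28 percentage points lower from compound 2 to compound 3 (beyond the scatter). For compound 3 a maximal response of 300% is estimated, within 220% to 380%.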

Compound 3, largest response reached (Emax), in percent of the reference or control that the assay uses: 330%
Compound 3: the middle estimate sits 30 percentage points below what was measured, within the range that was stated.
By their numbers in this assay, from the lowest: compound 1; then compounds 2 and 3 (each within the scatter of the next).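

In this assay, replacing 2-chlorophenyl with 2,6-difluorophenyl on the saturated ring carbon gives a number 2 percentage points higher from compound 2 to compound 3 (within the scatter), so these two substituted phenyls cannot be told apart on maximal response. The comparison with the bare phenyl gives a number 69 percentage points higher from compound 1 to compound 3 (beyond the scatter), which sets a second halogen-bearing aryl group clear of compound 1 and shows that, in this pair of substituted phenyls, the larger response is not confined to the 2-chlorophenyl of compound 2. No measurement at hand accounts for the match between chlorine and fluorine substitution or for the rise over the bare phenyl.

From the compounds shown here alone, whether a halogen is needed at all remains open: a methyl or methoxy group on the phenyl, or a pyridine ring in its place, would address that question. The shared core is also unchanged across all compounds shown, so it remains unknown whether the same rise over the bare phenyl would hold with a nitrile in place of the trifluoromethyl group.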